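A few compounds are considered here, and "the series" means these few. Any claim that something is new, unique, unknown or untested is made for them only; others in the source may bear on it.

Working notes on the series. For the measured compounds named here, compound 2 `COc1cccc(/C(C)=N/Nc2ncc(Cl)c(Nc3cccc(NC(=O)/C=C/CN(C)C)c3)n2)c1` sits at the lower end of the two numbers so far in an ADME assay on HT-29 cells (Homo sapiens) for inhibition, read by MTT assay, with a stated time of 72 h; on this read-out higher numbers stand for weaker inhibition and lower numbers for stronger inhibition: compound 2 gives 3870 nM, while compound 1 `CN(C)C/C=C/C(=O)Nc1cccc(Nc2nc(N/N=C/c3c[nH]c4ccccc34)ncc2Cl)c1` gives 9680 nM, and the step of a 2.5-fold lower number from compound 1 to compound 2 (0.40 log units; beyond the scatter) lies beyond the scatter. That single step exchanged the whole group on the hydrazone nitrogen, so it bears only loosely on the next change.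

Compound 3 `C/C(=N\Nc1ncc(Cl)c(Nc2cccc(NC(=O)/C=C/CN(C)C)c2)n1)c1ccccn1` differs from compound 2 by pyridin-2-yl in place of 3-methoxyphenyl on a carbon with a double bond to nitrogen. Both rings are six-membered aromatics with one acceptor, and the hydrazone carbon with its methyl stays in place. Going by the values given here, no measured pair isolates this kind of aryl swap, so no step beyond the scatter is expected in this assay, in either direction. Compound 3 is therefore estimated at 3000 nM, with a range of 800 nM to 12000 nM, which corresponds to an expected step of a 1.3-fold lower number from compound 2 to compound 3 (0.11 log units; within the scatter).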

Compound 3, half-maximal inhibitory concentration: 120 nM
Compound 3: middle estimate off by 25-fold (1.40 log units), on the high side; the measured number lies below the stated range.
By their numbers in this assay, from the lowest: compound 3; then compound 2; then compound 1.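

In this assay, pyridin-2-yl in place of 3-methoxyphenyl on a carbon with a double bond to nitrogen gives a 32-fold lower number from compound 2 to compound 3 (1.51 log units; beyond the scatter), so a change of the aryl group alone, with the methyl on that carbon kept, moves the number much further than the earlier 2.5-fold lower number from compound 1 to compound 2 (0.40 log units; beyond the scatter). The wider exchange of the group on the nitrogen on an aromatic ring gives an 81-fold lower number from compound 1 to compound 3 (1.91 log units; beyond the scatter), which shows that this position spans a far larger range than the first two compounds revealed. No measured evidence on hand accounts for the size of this step.

The compounds shown leave open whether the step follows the ring nitrogen of pyridin-2-yl or the loss of the methoxy group, as the two change together. Plain phenyl, pyridin-3-yl and pyridin-4-yl at this place would separate these two changes.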